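The source may hold more compounds than are shown below. What is called first, only, known or untested is meant among the compounds shown, and "the series" means these compounds.

Measured compounds:
Compound 1, `O=C(CSc1nc(Nc2ccccc2)c2ccccc2n1)Nc1ccc(Cl)cc1`, in a functional assay on MDA-MB-231 cells (Homo sapiens) for inhibition, read by MTT assay, with a stated time of 72 h; on this read-out lower numbers stand for stronger inhibition and higher numbers for weaker inhibition: 17200 nM
Compound 2, `O=C(CSc1nc(Nc2ccccc2)c2ccccc2n1)Nc1ccc(Cl)cc1Cl`, in this assay: 19400 nM

Compound 2 has the highest of these two numbers in this assay, but its nearest neighbour is compound 1, and the step of a 1.1-fold higher number from compound 1 to compound 2 (0.05 log units; within the scatter) lies within the scatter, so the two are not separated on this read-out. Compound 3, `O=C(CSc1nc(Nc2ccccc2)c2ccccc2n1)Nc1ccc(Cl)c(Cl)c1`, has not been measured. It differs from compound 2 only in where the two chlorines sit: 3,4-dichlorophenyl in place of 2,4-dichlorophenyl on an amide-type nitrogen. For the measured compounds named here, the one measured step that bears on this, a 1.1-fold higher number from compound 1 to compound 2 (0.05 log units; within the scatter), shows that adding a chlorine to this ring changed nothing beyond the scatter. Nothing measured here speaks to moving a chlorine from one place on the ring to another, so no step beyond the scatter is expected in either direction. Compound 3 is therefore expected to give about 18000 nM, in the range 8000 nM to 40000 nM, meaning a 1.1-fold lower number from compound 2 to compound 3 (0.03 log units; within the scatter).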

Compound 3, half-maximal inhibitory concentration: 14500 nM
Compound 3: the middle estimate sits 1.2-fold (0.09 log units) above what was measured; measured number inside the range.
By their numbers in this assay, from the lowest: compounds 3, 1 and 2 (each within the scatter of the next).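

Rearranging the two chlorines, with 3,4-dichlorophenyl in place of 2,4-dichlorophenyl on the amide-type nitrogen, gives in this assay a 1.3-fold lower number from compound 2 to compound 3 (0.13 log units; within the scatter), so this change does not separate the two compounds on this read-out. The earlier pair showed only that a second chlorine could be added to the ring of compound 1 without a clear effect; the new arrangement gives the same picture, with a 1.2-fold lower number from compound 1 to compound 3 (0.07 log units; within the scatter), so neither dichlorophenyl ring stands apart from the single-chlorine ring. No measurement here offers an explanation for this flat result.

Going by these compounds, all three compounds keep chlorine on this ring, so it remains open whether a methoxy group, an amine or a carboxylic acid there would move the number beyond the scatter. On these data alone, the effect of a longer chain between the sulfur and the carbonyl also remains open.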